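The source may hold more compounds than are shown below. What is called first, only, known or untested is meant among the compounds shown, and "the series" means these compounds.

Measured so far:
compound 1 `CN1C=CN(C2SC(C(Cl)(Cl)Cl)=CN2c2ccc(S(N)(=O)=O)cc2)C=C1` gives 88600 nM in an ADME assay for inhibition of prostaglandin G/H synthase 1 (Rattus norvegicus), with a stated time of 30 min; a higher number here means a weaker inhibitor, a lower number a stronger inhibitor
compound 2 `CN1C=CN(C2SC(C(F)(F)F)=CN2c2ccc(S(N)(=O)=O)cc2)C=C1` gives 52400 nM in this assay

Both numbers are high, so both compounds are weak inhibitors in this assay. Among the measured compounds shown here, the single step between them, a 1.7-fold lower number from compound 1 to compound 2 (0.23 log units; within the scatter), lies within the scatter. For the measured compounds named here, on the numbers seen, compound 2 has the lower of the two values, with compound 1 as the only neighbour and at a distance that is within the scatter, so no order between the two can be claimed.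

Compound 3 `CC1=CN(c2ccc(S(N)(=O)=O)cc2)C(N2C=CN(C)C=C2)S1` has not been measured. It differs from compound 2 by methyl in place of trifluoromethyl on a double-bonded ring carbon. Going by the values given here, no measured step exchanges trifluoromethyl for methyl. Among the compounds with values here, the only step that touches this position of the shared core is the one from compound 1 to compound 2, and it was within the scatter. Within the data shown here, on this basis a step of a 1.1-fold higher number from compound 2 to compound 3 (0.06 log units; within the scatter) is expected from compound 2 to compound 3, that is, none beyond the scatter, though with wide uncertainty since the step at hand has no direct precedent. Compound 3 is therefore estimated at 60000 nM in this assay, with a range from 20000 nM to 180000 nM.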

Compound 3, half-maximal inhibitory concentration in the prostaglandin G/H synthase 1 assay: 76900 nM
Estimate against measurement, compound 3: 1.3-fold (0.11 log units) below, and the stated range covers the measured number.
By their numbers in the prostaglandin G/H synthase 1 assay, from the lowest: compounds 2, 3 and 1 (each within the scatter of the next).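

In the prostaglandin G/H synthase 1 assay, the exchange of trifluoromethyl for methyl shows a 1.5-fold higher number from compound 2 to compound 3 (0.17 log units; within the scatter) and the exchange of trichloromethyl for methyl shows a 1.2-fold lower number from compound 1 to compound 3 (0.06 log units; within the scatter), so with compound 3 the three groups on this double-bonded ring carbon cannot be told apart, even though methyl has 1 heavy atom and trifluoromethyl has 4 heavy atoms. In a physicochemical assay for acid dissociation, compound 2 gives 7.5 and compound 3 gives 7.2, and the same exchange shows a number 0.30 log units lower from compound 2 to compound 3 (within the scatter), so neither read-out separates methyl from trifluoromethyl at this position. Nothing on hand offers an explanation for this flat result at the position.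

The three compounds shown carry only methyl and two trihalomethyl groups here, so it remains open whether an amine, a carboxylic acid or a longer chain on this same ring carbon would move the number in the prostaglandin G/H synthase 1 assay beyond the scatter. Also open, going by these compounds, is whether any change elsewhere on the shared core would do so, as all three compounds are alike outside this one position.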